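Swapping a Phenyl for a Piperidinyl Ring on the Sulfonamide

This account rests on a few compounds, and the source may have more. Where it says the series, first, only, none or still open, it means among the compounds named here.

Of the compounds shown here, three sharing one core have been measured so far. Compound 1 `Cc1ccc2[nH]c(C(=O)N[C@H]3CN(S(=O)(=O)c4ccccc4)C[C@@H]3C(=O)NCCN(C)C)cc2c1` gives 16 uL/min in an ADME assay on cells (Hepatocyte, Rattus norvegicus) for metabolic stability; on this read-out higher numbers stand for fast clearance and lower numbers for slow clearance. Compound 2 `Cc1ccc2[nH]c(C(=O)N[C@H]3CN(S(=O)(=O)C4CCOCC4)C[C@@H]3C(=O)NCCN(C)C)cc2c1` gives 4 uL/min, and the only difference between them, oxan-4-yl in place of phenyl on a sulfonyl sulfur, accounts for a 4.0-fold lower number from compound 1 to compound 2 (0.60 log units; beyond the scatter). Compound 3 `Cc1ccc2[nH]c(C(=O)N[C@H]3CCN(S(=O)(=O)c4ccccc4)C[C@@H]3C(=O)NCCN(C)C)cc2c1` gives 16 uL/min, level with compound 1 at the digits shown, and together with it the highest of the three numbers; compound 2 is the furthest away.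

Compound 4 `Cc1ccc2[nH]c(C(=O)N[C@H]3CCN(S(=O)(=O)N4CCCCC4)C[C@@H]3C(=O)NCCN(C)C)cc2c1` differs from compound 3 at the same position: piperidin-1-yl in place of phenyl on a sulfonyl sulfur. Within the data shown here, the only measured step that bears on this is the one from compound 1 to compound 2, where a six-membered non-aromatic ring with one hetero atom replaced phenyl on the same sulfonyl sulfur and the number fell modestly. A fall of similar size is therefore expected here, giving a 2.7-fold lower number from compound 3 to compound 4 (0.43 log units; beyond the scatter). Compound 4 is expected to show about 6 uL/min, with a likely range from 3 uL/min to 14 uL/min.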

Compound 4, intrinsic clearance in a liver preparation (reported as CLH), per the amount of preparation that the assay uses: 25 uL/min
The estimate for compound 4 lay 4.2-fold (0.62 log units) below the measured number; measured number outside the range, above it.
By their numbers in this assay, from the lowest: compound 2; then compounds 1, 3 and 4 (each within the scatter of the next).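

Putting piperidin-1-yl in place of phenyl on the sulfonyl sulfur gives a 1.6-fold higher number from compound 3 to compound 4 (0.19 log units; within the scatter) in this assay and so does not repeat the fall seen with oxan-4-yl, which gave a 4.0-fold lower number from compound 1 to compound 2 (0.60 log units; beyond the scatter) on the core of compound 1. A six-membered non-aromatic ring in place of phenyl is therefore not enough on its own to lower this number: compound 2 fits that idea, and compound 4 goes against it. Nothing available here accounts for the difference between these two swaps.

The two swaps differ both in the ring that enters and in the core that carries it, so the compounds shown cannot tell which of these matters. Also open, going by these compounds, is how a morpholin-4-yl group, which holds both a ring oxygen and a ring nitrogen, would behave in place of phenyl on compound 3.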